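The source may report more compounds than this note shows. Statements on the series, on what has been measured and on what is new or still open speak of the compounds shown alone.

Measured so far:
- compound 1 `COc1ccccc1CNC(=O)c1ccc2c[n+]([O-])ccc2n1`: 100 ug/mL
- compound 2 `COc1ccccc1CNC(=O)c1ccc2c(N)nccc2n1`: about 12.5 ug/mL

In a functional assay on Hs68 cells (Homo sapiens) for inhibition (on this read-out higher numbers stand for lower toxicity in this test and lower numbers for higher toxicity in this test), compound 2 gives about 12.5 ug/mL, the lower of the two numbers and therefore the higher toxicity in this small set. Compound 1 gives 100 ug/mL, and the gap between the two lies beyond the usual scatter. Among the measured compounds shown here, these compounds do not differ in a single place, so no measured one-place step is available to guide the next estimate.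

The next compound to be tested is compound 3 `COc1ccccc1CNC(=O)c1ccc2c(OC)nccc2n1`. It keeps the shared core of compound 2 and carries methoxy in place of amino on an aromatic carbon, next to the ring nitrogen: methoxy in place of amino on an aromatic carbon.

For the measured compounds named here, with no measured precedent for this exchange, only a modest move towards higher numbers in this assay is expected, perhaps just beyond the scatter. The value of compound 1 at 100 ug/mL serves as a rough upper reference. The expected change is a 2.2-fold higher number from compound 2 to compound 3 (0.35 log units; beyond the scatter). For compound 3 the estimated value is 28 ug/mL, with an expected range of 10 ug/mL to 90 ug/mL.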

Compound 3, half-maximal cytotoxic concentration: > 50 ug/mL
Compound 3 was reported as a limit; the forecaster's own chance of this, stated with the estimate: 10%; middle value at least 1.7-fold (0.25 log units) away from the limit.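

In this assay compound 3 gives > 50 ug/mL, which is a limit of the assay and not a number. Among the compounds shown here, on this aromatic carbon, next to the ring nitrogen, methoxy in place of amino gives an at least 4.0-fold higher number from compound 2 to compound 3 (0.60 log units; beyond the scatter): this is the first measured one-place step, and it shows that the group on this carbon alone can move the read-out beyond the scatter, with amino on the side of higher toxicity in this test. The step fixes only a lower bound on the size of the change, and its full size stays unknown, because the value at its upper end is censored: the limit of > 50 ug/mL in this assay, at which 1 of the 3 values shown sits.

This one pair does not separate the departure of the hydrogen-bond donor of amino from the entry of the larger methoxy, as both change together. Open as well is how a methylamino group, a hydroxy group or a longer ethoxy chain on the same carbon would read in this assay, and whether the step would hold on a different core.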